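A few compounds are considered here, and "the series" means these few. Any claim that something is new, unique, unknown or untested is made for them only; others in the source may bear on it.

Working notes on the series. Compound 1 `O=C1CSC(c2ccc(F)cc2)N1CCN1CCCCC1` carries fluoro on the shared core, compound 2 `COc1ccc(C2SCC(=O)N2CCN2CCCCC2)cc1` carries methoxy and compound 3 `O=C1CSC(c2ccc([N+](=O)[O-])cc2)N1CCN1CCCCC1` carries nitro. In an ADME assay on Vero cells (Chlorocebus sabaeus) for cytotoxicity, read by neutral red uptake, tested at 3150 ug/mL (a lower number here means a stronger effect, a higher number a weaker effect of the compound at the concentration tested), compound 1 gives 11%, compound 2 gives 11% and compound 3 gives 10%. On these numbers compound 3 lies within the scatter of both others: a number 1 percentage points lower from compound 1 to compound 3 (within the scatter) and a number 1 percentage points lower from compound 2 to compound 3 (within the scatter). Compound 4 `Cc1ccc(C2SCC(=O)N2CCN2CCCCC2)cc1` follows from compound 3 by methyl in place of nitro on an aromatic carbon. The measured steps that bear on this change are the two in which nitro replaced fluoro or methoxy, each within the scatter, so no step beyond the scatter is expected in this assay, in either direction. For compound 4 the estimated value is 11%, with a range from 4% to 18%. This amounts to an expected step of a number 1 percentage points higher from compound 3 to compound 4 (within the scatter).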

Compound 4, a percentage reported as activity, at one concentration (the size of the read-out at that concentration, not a potency): 12%
The estimate for compound 4 lay 1 percentage points below the measured number, and the stated range covers the measured number.
By their numbers in this assay, from the lowest: compounds 3, 1, 2 and 4 (each within the scatter of the next).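

In this assay methyl on this aromatic carbon, para to a large group, does not separate from nitro (a number 2 percentage points higher from compound 3 to compound 4 (within the scatter)), from methoxy (a number 1 percentage points higher from compound 2 to compound 4 (within the scatter)) or from fluoro (a number 1 percentage points higher from compound 1 to compound 4 (within the scatter)). Even the exchange of nitro for a single carbon with no hydrogen-bond acceptors leaves the read-out unresolved from the other compounds. Nothing available explains why these four compounds read alike. Going by these compounds, whether an amine or a carboxylic acid at this place would also stay within the scatter remains open.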